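The source may hold more compounds than are shown below. What is called first, only, known or untested is meant among the compounds shown, and "the series" means these compounds.

Within the data shown here, compound 3 `COc1cccc(OC)c1OCCNCCOc1ccccc1OCc1ccc(Cl)cc1` stands lowest among the three numbers measured so far: in an assay on CHO cells for displacement of a labelled ligand from Alpha-1D adrenergic receptor (Homo sapiens) (a lower number here means a stronger inhibitor, a higher number a weaker inhibitor), compound 3 gives 0.0316 nM, while compound 1 `COc1cccc(OC)c1OCCNCCOc1ccccc1OCc1ccccc1` gives 0.0676 nM and compound 2 `COc1cccc(OC)c1OCCNCCOc1ccccc1OCc1ccccc1Cl` gives 0.251 nM. The steps of a 2.1-fold lower number from compound 1 to compound 3 (0.33 log units; beyond the scatter) and a 3.7-fold higher number from compound 1 to compound 2 (0.57 log units; beyond the scatter) show that a chloro on the benzyl ring moves the number only modestly, and a 7.9-fold lower number from compound 2 to compound 3 (0.90 log units; beyond the scatter) shows the larger of the two effects. Compound 4 `COc1cccc(OC)c1OCCNCCOc1ccccc1OCc1ccc(C)cc1` differs from compound 3 by methyl in place of chloro on an aromatic carbon. Among the measured compounds shown here, no measured step exchanges chloro for methyl, so only the modest size of a 2.1-fold lower number from compound 1 to compound 3 (0.33 log units; beyond the scatter) bears on it; a small step, within or near the scatter, is expected. Compound 4 is therefore estimated at 0.05 nM, between 0.02 nM and 0.13 nM, a step of a 1.6-fold higher number from compound 3 to compound 4 (0.20 log units; within the scatter).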

Compound 4, inhibition constant: 0.0631 nM
Estimate against measurement, compound 4: 1.3-fold (0.10 log units) below; low and high end bracket the measured number.
By their numbers in this assay, from the lowest: compounds 3, 4 and 1 (each within the scatter of the next, the first and the last beyond it); then compound 2.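

On this aromatic carbon, methyl and chloro cannot be told apart, with a 2.0-fold higher number from compound 3 to compound 4 (0.30 log units; within the scatter). Methyl in place of hydrogen gives a 1.1-fold lower number from compound 1 to compound 4 (0.03 log units; within the scatter), so this change leaves no separation from the unsubstituted benzyl compound, while 4-methylphenyl in place of 2-chlorophenyl gives a 4.0-fold lower number from compound 2 to compound 4 (0.60 log units; beyond the scatter) and keeps compound 2 apart. Nothing shown gives a reason for these numbers. Going by these compounds, whether an amine or a carboxylic acid at this position would move the number remains open. So does whether 2-methylphenyl would stand with 2-chlorophenyl.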